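Swapping the aromatic cap on the shared core

A few compounds are considered here, and "the series" means these few. Any claim that something is new, unique, unknown or untested is made for them only; others in the source may bear on it.

Measured so far:
Compound 1 `O=C(O)CNC(=O)c1c(O)c2c(n(Cc3cc(F)c(F)cc3F)c1=O)COC2` gives 3.1 nM in an assay on Sf9 cells for inhibition of prolyl hydroxylase EGLN2 (Homo sapiens), read by TR-FRET, with stated times of 30 min and 2 h; on this read-out higher numbers stand for weaker inhibition and lower numbers for stronger inhibition.
Compound 2 `O=C(O)CNC(=O)c1c(O)c2c(n(Cc3cnc(C(F)(F)F)s3)c1=O)COC2` gives 2.4 nM in this assay.

Compound 2 carries the lowest of the two numbers shown, but its gap to compound 1 lies within the scatter, so the two values should be read as alike. For the measured compounds named here, the only measured step, a 1.3-fold lower number from compound 1 to compound 2 (0.11 log units; within the scatter), exchanged one aromatic group for another on the saturated chain carbon bound to an aromatic nitrogen and moved the number hardly at all.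

Compound 3 `O=C(O)CNC(=O)c1c(O)c2c(n(Cc3nc4ccccc4o3)c1=O)COC2` differs from compound 2 at the same place: 1,3-benzoxazol-2-yl in place of 2-(trifluoromethyl)-1,3-thiazol-5-yl on a saturated chain carbon bound to an aromatic nitrogen. Going by the values given here, the one step that bears on this, a 1.3-fold lower number from compound 1 to compound 2 (0.11 log units; within the scatter), suggests that the aromatic group at this position can be varied with little effect on the read-out. On that basis the estimated step of a 1.5-fold higher number from compound 2 to compound 3 (0.16 log units; within the scatter) is expected to stay within the scatter. Compound 3 is therefore expected to give about 3.5 nM in this assay, with a likely range from 1.5 nM to 9 nM.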

Compound 3, half-maximal inhibitory concentration: 5 nM
Estimate against measurement, compound 3: 1.4-fold (0.15 log units) below; low and high end bracket the measured number.
By their numbers in this assay, from the lowest: compounds 2, 1 and 3 (each within the scatter of the next, the first and the last beyond it).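

For the compounds shown here, exchanging the 2-(trifluoromethyl)-1,3-thiazol-5-yl group for 1,3-benzoxazol-2-yl gives the first step at this place in this assay to pass beyond the scatter, a 2.1-fold higher number from compound 2 to compound 3 (0.32 log units; beyond the scatter), so the aromatic group here is not entirely free to vary, although the effect is modest. The same 1,3-benzoxazol-2-yl group set against the 2,4,5-trifluorophenyl group gives a 1.6-fold higher number from compound 1 to compound 3 (0.21 log units; within the scatter), so whether this change counts as a real difference depends on which group it is compared with. The 2-(trifluoromethyl)-1,3-thiazol-5-yl and 1,3-benzoxazol-2-yl groups match in heavy atoms, hydrogen-bond donors and hydrogen-bond acceptors, so those counts do not separate them, and no measurement at hand explains the gap.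

The compounds shown leave open whether the fused carbon ring of 1,3-benzoxazol-2-yl matters, which a plain 1,3-oxazol-2-yl group at this place would test. All three groups here are aromatic, so they also leave open how a cyclohexyl ring or a chain ending in an amine would read on this carbon.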